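Adding a chloro to the benzoyl arm of compound 1

A few compounds are considered here, and "the series" means these few. Any claim that something is new, unique, unknown or untested is made for them only; others in the source may bear on it.

Compounds measured so far, all in a functional assay on A549 cells (Homo sapiens) for cytotoxicity, read by MTT assay, with a stated time of 48 h; a lower number here means a stronger inhibitor, a higher number a weaker inhibitor:
compound 1 `COc1cc(-c2nnc3n2NC(c2cccs2)C(C(=O)c2ccccc2)S3)cc(OC)c1OC` gives 69400 nM;
compound 2 `COc1cc(-c2nnc3n2NC(c2ccco2)C(C(=O)c2cccs2)S3)cc(OC)c1OC` gives 78700 nM;
compound 3 `COc1cc(-c2nnc3n2NC(c2ccco2)C(C(=O)c2ccccc2F)S3)cc(OC)c1OC` gives 78700 nM.

Among these three numbers, compound 1 has the lowest, but its gaps to compound 2 and to compound 3 are both within the usual scatter, so no order among the three compounds can be claimed. Among the measured compounds shown here, only one single-point step is available: no change at the digits printed from compound 2 to compound 3 (within the scatter), which exchanges the group on the carbonyl carbon while leaving the rest of the shared core untouched.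

Compound 4 `COc1cc(-c2nnc3n2NC(c2cccs2)C(C(=O)c2ccc(Cl)cc2)S3)cc(OC)c1OC` is derived from compound 1 by the change (chloro in place of hydrogen on an aromatic carbon). For the measured compounds named here, no measured step shows this exact change. The step from compound 2 to compound 3 is the nearest comparison, since it also alters the aromatic group on the carbonyl carbon, and it produced no shift beyond the scatter. Going by the values given here, with only that guide, and with all three measured compounds lying so close together, the expectation for compound 4 is a step of a 1.0-fold higher number from compound 1 to compound 4 (0.00 log units; within the scatter) that stays within the scatter, in no particular direction.

Compound 4 is therefore estimated at 70000 nM, with a range from 35000 nM to 140000 nM.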

Compound 4, half-maximal inhibitory concentration: 20100 nM
For compound 4 the middle estimate is 3.5-fold (0.54 log units) above the measured one; the measured number lies below the stated range.
By their numbers in this assay, from the lowest: compound 4; then compounds 1, 2 and 3 (each within the scatter of the next).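

In this assay the change from phenyl to 4-chlorophenyl gives a 3.5-fold lower number from compound 1 to compound 4 (0.54 log units; beyond the scatter) and is the first step among the compounds shown to lie beyond the scatter. Among the compounds shown here, the only earlier step, no change at the digits printed from compound 2 to compound 3 (within the scatter) on the group at the carbonyl carbon, gave no reading of any change, so this result is the first sign that a substituent on this aromatic arm can move the cytotoxicity number at all, here with a single chlorine atom entering para to a large group. Nothing measured alongside these numbers accounts for the step, and it remains an observation without an explanation.

The compounds shown do not tell whether the step is particular to chloro or would also follow from a bromo, a methoxy group or an amine at the same place on the ring. They also leave open whether chloro would give a similar step in the setting of compound 2 or compound 3, so the effect rests on one pair of compounds and cannot yet be called a trend.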